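A few compounds are considered here, and "the series" means these few. Any claim that something is new, unique, unknown or untested is made for them only; others in the source may bear on it.

In an assay on isolated protein for inhibition of sulfide:quinone oxidoreductase, mitochondrial (Homo sapiens) (a lower number here means a stronger inhibitor, a higher number a weaker inhibitor), the measured compounds stand as follows:
Compound 1, `COc1ccc(-c2cc(-c3ccc(F)cc3)c(C#N)c(OC)n2)cc1`, gives 1360 nM.
Compound 2, `COc1nc(-c2ccccn2)cc(C(C)(C)C)c1C#N`, gives 850 nM.
Compound 3, `COc1nc(-c2ccncc2)cc(-c2ccc(F)cc2)c1C#N`, gives 17400 nM.

Compound 3 stands highest of the three in this assay; its nearest neighbour is compound 1 and its furthest is compound 2, and both gaps lie beyond the scatter. Compound 4 is `COc1nc(-c2ccccn2)cc(-c2ccc(F)cc2)c1C#N`; it has the same atoms as compound 3 joined differently, the difference being (pyridin-2-yl in place of pyridin-4-yl on an aromatic carbon). Going by the values given here, only one measured step touches the same position: a 13-fold higher number from compound 1 to compound 3 (1.11 log units; beyond the scatter), in which the 4-methoxyphenyl group gave way to the pyridin-4-yl group and the number rose sharply. Compound 2 also carries a pyridin-2-yl group at this position and gives a low number, but it differs from compound 3 in a second place as well, so its value is no more than a hint that the pyridin-2-yl group can sit there with a lower number. On that basis a lower number is expected for compound 4, with wide uncertainty, as the step of a 7.0-fold lower number from compound 3 to compound 4 (0.84 log units; beyond the scatter). Compound 4 is therefore estimated at 2500 nM, with a range from 800 nM to 8000 nM.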

Compound 4, half-maximal inhibitory concentration: 14 nM
For compound 4 the middle estimate is 180-fold (2.25 log units) above the measured one, outside the stated range (below it).
By their numbers in this assay, from the lowest: compound 4; then compounds 2 and 1 (each within the scatter of the next); then compound 3.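

In this assay, moving the ring nitrogen of the group next to the ring nitrogen of the shared core is enough to give a very large change (a 1200-fold lower number from compound 3 to compound 4 (3.09 log units; beyond the scatter)), although pyridin-2-yl and pyridin-4-yl have the same counts of heavy atoms and hydrogen-bond acceptors. The earlier step had shown only that pyridin-4-yl did worse than 4-methoxyphenyl, whereas pyridin-2-yl does better than that group (a 97-fold lower number from compound 1 to compound 4 (1.99 log units; beyond the scatter)), so among these three groups with a 4-fluorophenyl partner, the position favours pyridin-2-yl and the outcome turns on the nitrogen's place rather than on the presence of a nitrogen alone. With pyridin-2-yl held fixed, the other position also matters strongly, as 4-fluorophenyl in place of tert-butyl shows (a 61-fold lower number from compound 2 to compound 4 (1.78 log units; beyond the scatter)), and the low number of compound 2 therefore marked no floor for this series.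

Nothing available here accounts for the size of the gap between the two pyridinyl isomers. The compounds shown also leave open where a pyridin-3-yl group would fall relative to these two isomers, and whether a pyrimidin-2-yl group would keep the low number of compound 4.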